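A few compounds are considered here, and "the series" means these few. Any claim that something is new, unique, unknown or untested is made for them only; others in the source may bear on it.

Working notes on the series. Going by the values given here, in a functional assay on K562 cells (Homo sapiens) for cytotoxicity, read by fluorescence, with a stated time of 72 h (a lower number here means a stronger inhibitor, a higher number a weaker inhibitor), compound 1 (`Nc1n[nH]c(N)c1/N=N/c1ccc(O)cc1`) gives 33000 nM and this is the only true number so far. Compound 2 (`Nc1n[nH]c(N)c1/N=N/c1cc[n+]([O-])cc1`) reads > 100000 nM in this assay and that entry is a limit of the assay, not a number. Among the compounds with values here, the data thus hold a single number to work from, with the other entry recorded as the limit of > 100000 nM in this assay, at which 1 of the 2 values shown sits, and no measured step to set a scale.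

Compound 3 (`Cn1nc(N)c(/N=N/c2ccc(O)cc2)c1N`) is the next to be read. Its difference from compound 1 is methyl in place of hydrogen on an aromatic nitrogen and it places a methyl in place of hydrogen on an aromatic nitrogen, with the rest of the core of compound 1 unchanged.

Within the data shown here, with no measured step for comparison, the expectation rests on the structural change alone and on compound 1 at 33000 nM as the starting point. A small shift in this assay towards weaker inhibition is expected, not clearly beyond the scatter. The expected move is a 1.5-fold higher number from compound 1 to compound 3 (0.18 log units; within the scatter) as an estimate only. For compound 3 the estimated value is 50000 nM with an expected range from 18000 nM to 120000 nM as the working bracket.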

Compound 3, half-maximal inhibitory concentration: 98500 nM
Beside the measured number, compound 3's estimate is 2.0-fold (0.29 log units) below it, within the range that was stated.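

Going by these compounds alone, the first measured step falls on an aromatic nitrogen of the five-membered aromatic ring: in this assay, methyl in place of hydrogen there gives a 3.0-fold higher number from compound 1 to compound 3 (0.47 log units; beyond the scatter). This shows that the position is not indifferent to the change, since even this single added carbon moves the number by more than the scatter, and it gives the series its only scale so far, drawn from one pair of compounds. The entry for compound 2 is a limit of the assay and not a number, and compound 3 now reads close to that limit, so any further weakening from compound 3 has little room left to appear as a true number: the limit of > 100000 nM in this assay, at which 1 of the 3 values shown sits.

Within the data shown here, the single pair does not separate the effect of adding the methyl from that of losing the hydrogen on this nitrogen, and it gives no trend with group size. An ethyl group or a longer chain on the same nitrogen would test whether the number keeps rising with chain length, though such readings could reach the limit of this assay.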